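This account rests on a few compounds, and the source may have more. Where it says the series, first, only, none or still open, it means among the compounds named here.

Compound 3 `O=C(O)C(=O)Nc1nc(-c2cc(Cl)no2)cs1` stands at > 30 mg/kg in a functional assay on the whole organism with Rattus norvegicus as the target (a lower number here means that less compound is needed, a higher number that more compound is needed for the effect), and this is a limit of the assay, not a number. Compound 4 `COc1cc(-c2csc(NC(=O)C(=O)O)n2)on1` carries methoxy in place of chloro on an aromatic carbon. Compound 1 `CCOCCOC(=O)C(=O)Nc1nc(-c2cc(Cl)no2)cs1` gives 6 mg/kg and compound 2 `CCOCCOC(=O)C(=O)Nc1nc(-c2cc(OC)no2)cs1` gives 3 mg/kg. That pair shows the same exchange, measured as a 2.0-fold lower number from compound 1 to compound 2 (0.30 log units; within the scatter). Hydrogen in place of 2-ethoxyethyl gave an at least 5.0-fold higher number from compound 1 to compound 3 (0.69 log units; beyond the scatter), and compound 4 keeps that hydrogen. Only the first of these steps bears on the exchange itself, so no change beyond the scatter is expected in this assay. The expected step is a number no higher from compound 3 to compound 4 (the limit leaves the size open). For compound 4 the estimate is 30 mg/kg, with an expected range of 12 mg/kg to 60 mg/kg.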

Compound 4, dose for half-maximal effect: 1.2 mg/kg
Compound 4: the middle estimate sits 25-fold (1.40 log units) above what was measured, and the stated range ends above it.
By their numbers in this assay, from the lowest: compound 4; then compounds 2 and 1 (each within the scatter of the next). At a limit, above all of these: compound 3.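

In this assay, methoxy in place of chloro on an aromatic carbon is not a neutral exchange on every core, as it gives an at least 25-fold lower number from compound 3 to compound 4 (1.39 log units; beyond the scatter): the same change on two cores in this assay, a 2.0-fold lower number (0.30 log units; within the scatter) from compound 1 to compound 2 and an at least 25-fold lower number (1.39 log units; beyond the scatter) from compound 3 to compound 4, at least 12-fold (1.09 log units) apart, beyond the scatter of two such steps. Hydrogen in place of 2-ethoxyethyl also changes direction with the group at this position, giving a 2.5-fold lower number from compound 2 to compound 4 (0.40 log units; beyond the scatter): the same change on two cores in this assay, an at least 5.0-fold higher number (0.69 log units; beyond the scatter) from compound 1 to compound 3 and a 2.5-fold lower number (0.40 log units; beyond the scatter) from compound 2 to compound 4, at least 12-fold (1.09 log units) apart, beyond the scatter of two such steps. From the compounds shown here alone, the value of compound 3 is a limit of the assay, so the size of the step from it stays open.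

Going by these compounds, whether this core dependence extends to an amine or an ethoxy group at this position remains open. So does its behaviour with a shorter ester chain, such as methyl.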